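Swapping the Aryl Group on a Tetrazole Acetamide

The compounds below may be only part of what the source reports. "The series", "measured", "known", "first", "only" and "open" are said of these compounds alone.

compound 1 `Cc1cc(NC(=O)Cn2nnc(-c3ccccc3)n2)n(C2CCCC2)n1`: 105%
compound 2 `O=C(Cn1nnc(-c2ccccc2)n1)Nc1cc(C2(C(F)(F)F)CC2)nn1C1CCCCC1`: "not active" (no number reported)
compound 3 `Cc1cc(NC(=O)Cn2nnc(-c3ccc(F)c(F)c3)n2)n(C2CCCCC2)n1`: 93%

Of the compounds shown here, three have been tested in an assay on HEK293 cells for activation of Kir3.1/Kir3.2 (Homo sapiens), read by thallium flux; on this read-out higher numbers stand for larger maximal responses and lower numbers for smaller maximal responses. Compound 1 `Cc1cc(NC(=O)Cn2nnc(-c3ccccc3)n2)n(C2CCCC2)n1` gives 105%. Compound 2 `O=C(Cn1nnc(-c2ccccc2)n1)Nc1cc(C2(C(F)(F)F)CC2)nn1C1CCCCC1` gives "not active" (no number reported), so no number is reported for it. Compound 3 `Cc1cc(NC(=O)Cn2nnc(-c3ccc(F)c(F)c3)n2)n(C2CCCCC2)n1` gives 93%; this is the lower of the two numbers, and compound 1 sits above it by a gap beyond the usual scatter.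

Compound 4 `Cc1cc(NC(=O)Cn2nnc(-c3cccc(C#N)c3)n2)n(C2CCCCC2)n1` is not yet measured. It differs from compound 3 in one place: 3-cyanophenyl in place of 3,4-difluorophenyl on an aromatic carbon. For the measured compounds named here, no measured pair differs in exactly one place, so no measured step guides this change. In this assay the step from compound 3 to compound 4 is expected to be small, within the scatter, with no clear direction: a number 5 percentage points lower from compound 3 to compound 4 (within the scatter). Compound 4 is therefore estimated at 88%, with a range from 55% to 115%. The missing number for compound 2 shows that a loss of response cannot be ruled out.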

Compound 4, largest response reached (Emax), in percent of the reference or control that the assay uses: 80%
The estimate for compound 4 lay 8 percentage points above the measured number; measured number inside the range.
By their numbers in this assay, from the lowest: compound 4; then compound 3; then compound 1.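

In this assay, the change from 3,4-difluorophenyl to 3-cyanophenyl on an aromatic carbon of the five-membered aromatic ring with 4 nitrogen gives the first readable single-place step: a number 13 percentage points lower from compound 3 to compound 4 (beyond the scatter). This shows that the maximal response depends on the aryl group at this position, although compound 4 still gives a clear response of 80% in this assay. No measurement shown here explains the drop.

Going by these compounds, it remains open whether the lower number comes from gaining the nitrile or from losing the two fluorine atoms. It is also unknown how the response would change with a 3-aminophenyl or 3-methoxyphenyl group at this position, or with a carboxylic acid on the phenyl ring in place of the nitrile.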